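Methyl Added to a Non-Toxic Pyrazolyl-Methylamino Triazine Series

A few compounds are considered here, and "the series" means these few. Any claim that something is new, unique, unknown or untested is made for them only; others in the source may bear on it.

Measured so far:
Compound 1 `c1ccc(-c2cc(CNc3nncc(-c4cccc5ccccc45)n3)n[nH]2)cc1`: > 10000 nM
Compound 2 `c1ccc(-c2cnnc(NCc3cc(-c4ccccc4)[nH]n3)n2)cc1`: > 10000 nM

Compound 1 `c1ccc(-c2cc(CNc3nncc(-c4cccc5ccccc45)n3)n[nH]2)cc1` and compound 2 `c1ccc(-c2cnnc(NCc3cc(-c4ccccc4)[nH]n3)n2)cc1` were tested in an ADME assay on CEM174 cells (Homo sapiens) for cytotoxicity; on this read-out higher numbers stand for lower toxicity in this test and lower numbers for higher toxicity in this test. For compound 1 the result is a limit of the assay, > 10000 nM, not a number. For compound 2 the result is likewise a limit of the assay, > 10000 nM. Both readings therefore sit at the same limit, and nothing more can be said about where compound 2 stands relative to compound 1; the limit of > 10000 nM in this assay, at which 2 of the 2 values shown sit, summarises this.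

Compound 3 `Cc1ccccc1-c1cnnc(NCc2cc(-c3ccccc3)[nH]n2)n1` has not yet been tested. It differs from compound 2 by methyl in place of hydrogen on an aromatic carbon, a methyl in place of hydrogen on an aromatic carbon. Among the measured compounds shown here, no measured pair shows such a step here. The expected step from compound 2 to compound 3 is a step that the limit leaves unreadable from compound 2 to compound 3, that is, none beyond the scatter, with the reading most likely remaining at the limit. For compound 3 the estimate is 20000 nM, in the range 8000 nM to 60000 nM.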

Compound 3, half-maximal cytotoxic concentration: > 10000 nM
Compound 3: a limit, no number; the forecaster's own chance of this, stated with the estimate: 85%; the middle value lies beyond the limit too.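

In this assay, among the compounds shown here, compound 2 and compound 3 both give only a limit of the assay, so no step between them can be read. The compounds shown leave open whether methyl in place of hydrogen changes this read-out at all, and all share one reading: the limit of > 10000 nM in this assay, at which 3 of the 3 values shown sit.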